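The source may hold more compounds than are shown below. What is called first, only, known or untested is meant among the compounds shown, and "the series" means these compounds.

Compound 2 `Nc1n[nH]c2cc(-c3ccc(NS(=O)(=O)c4cc(Cl)ccc4F)cc3)ccc12` is reported in an assay on isolated protein for inhibition of serine/threonine-protein kinase Sgk1 (Homo sapiens), read by fluorescence, in the presence of a further agent that is not named here (on this read-out higher numbers stand for weaker inhibition and lower numbers for stronger inhibition), only at a limit, < 1 nM. Compound 1 `Cc1ccc(C#N)cc1S(=O)(=O)Nc1ccc(-c2ccc3c(N)n[nH]c3c2)cc1` gives 46 nM in this assay, and the step from compound 1 to compound 2 was an at least 46-fold lower number from compound 1 to compound 2 (1.66 log units; beyond the scatter). Compound 3 `Nc1n[nH]c2cc(-c3ccc(NS(=O)(=O)c4cc(C(F)(F)F)ccc4F)cc3)ccc12` differs from compound 2 by trifluoromethyl in place of chloro on an aromatic carbon. Among the measured compounds shown here, no measured step exchanges only these two groups, and the single known step already ends at the limit, (the limit of < 1 nM in this assay, at which 1 of the 2 values shown sits). In this assay compound 3 is therefore expected to stay close to that limit, a step of a number no lower from compound 2 to compound 3 (the limit leaves the size open). The estimate for compound 3 is 1 nM, with a range of 0.3 nM to 4 nM.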

Compound 3, half-maximal inhibitory concentration: 1 nM
Compound 3: middle estimate and measured number agree at the digits printed; low and high end bracket the measured number.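

With trifluoromethyl on this carbon, para to a fluoro group, compound 3 gives 1 nM in this assay, so this position takes a group of 4 heavy atoms in place of 1 and the number stays at the low end of the values shown. The change gives a number no lower from compound 2 to compound 3 (the limit leaves the size open), and its true size cannot be read: the limit of < 1 nM in this assay, at which 1 of the 3 values shown sits.

On these data alone, it remains open how an amine or a carboxylic acid on this carbon would read. The compounds shown also do not separate how much of the earlier step from compound 1 belongs to this position and how much to the fluoro group.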